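Aryl exchange on the acid compound 3

A few compounds are considered here, and "the series" means these few. Any claim that something is new, unique, unknown or untested is made for them only; others in the source may bear on it.

- compound 1 `CCOc1ccccc1-c1ccc(-c2nc3cnccc3c(N)c2C#N)cc1`: 3
- compound 2 `CCCCC(Nc1c(C#N)c(-c2ccc(-c3ccccc3OCC)cc2)nc2cnccc12)C(N)=O`: 3.6
- compound 3 `CC[C@@H](Nc1c(C#N)c(-c2ccc(-c3cccc(Cl)c3F)cc2)nc2cnccc12)C(=O)O`: 2.2

In a physicochemical assay for lipophilicity, read by HPLC, at pH 7.5 (a higher number here means a more lipophilic compound, a lower number a more polar compound), compound 3, at 2.2, stands lowest of the three. Its gaps up to compound 1 and compound 2 both lie beyond the scatter.

Compound 4 `CCOc1ccccc1-c1ccc(-c2nc3cnccc3c(N[C@H](CC)C(=O)O)c2C#N)cc1` differs from compound 3 at one place: 2-ethoxyphenyl in place of 3-chloro-2-fluorophenyl on an aromatic carbon. The substituent on the nitrogen stays the same.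

Within the data shown here, the only measured step, a number 0.60 log units higher from compound 1 to compound 2 (beyond the scatter), is modest and beyond the scatter, but it is a change on the nitrogen and not on this aromatic carbon. It therefore bears on the exchange only weakly. Compound 1 and compound 2 do carry the 2-ethoxyphenyl group, yet each also differs from compound 3 in the substituent on the nitrogen, so their gaps to compound 3 cannot be assigned to the aromatic group alone. Among the measured compounds shown here, no measured pair isolates this exchange.

On these data alone, no step beyond the scatter is therefore expected in this assay, and the direction stays open. The expected step is a number 0.10 log units lower from compound 3 to compound 4 (within the scatter). For compound 4 the estimated value is 2.1, with an expected range from 1.6 to 2.6.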

Compound 4, distribution coefficient: 2.1
Beside the measured number, compound 4's estimate shows no gap at the digits printed; measured number inside the range.
By their numbers in this assay, from the lowest: compounds 4 and 3 (each within the scatter of the next); then compound 1; then compound 2.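

In this assay, the exchange is now isolated: 2-ethoxyphenyl in place of 3-chloro-2-fluorophenyl on an aromatic carbon, para to a large group, gives a number 0.10 log units lower from compound 3 to compound 4 (within the scatter) with 1-carboxypropyl held on the nitrogen, so this pair of aromatic groups is not told apart here. With 2-ethoxyphenyl held constant, the nitrogen substituent can also be read for the acid: 1-carboxypropyl in place of hydrogen gives a number 0.90 log units lower from compound 1 to compound 4 (beyond the scatter) and 1-carboxypropyl in place of 1-carbamoylpentyl gives a number 1.50 log units lower from compound 2 to compound 4 (beyond the scatter), a direction opposite to that of a number 0.60 log units higher from compound 1 to compound 2 (beyond the scatter) on the first of these changes. Among these four compounds, the steps beyond the scatter all sit on the nitrogen, and no measurement at hand accounts for any of them.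

On these data alone, whether the aromatic exchange stays this small with hydrogen or 1-carbamoylpentyl on the nitrogen remains open, as 3-chloro-2-fluorophenyl appears only with 1-carboxypropyl. Also open, as far as these compounds go, is the reading for an amine in place of the carboxylic acid, or for a carboxylic acid on a longer chain, at the same nitrogen.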